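Series notes on four alkylamino analogues

The compounds below may be only part of what the source reports. "The series", "measured", "known", "first", "only" and "open" are said of these compounds alone.

Values in a functional assay (aorta) with Rattus norvegicus as the target; on this read-out lower numbers stand for an effect already at smaller amounts and higher numbers for an effect only at larger amounts of compound:
- compound 1 `CCNC1=NS(=O)(=O)c2cc(F)ccc2N1` gives > 300 uM, which is a limit of the assay and not a number.
- compound 2 `CC(C)NC1=NS(=O)(=O)c2cc(F)ccc2N1` gives 43.1 uM.
- compound 3 `CCNC1=NS(=O)(=O)c2cc(Cl)ccc2N1` gives 39.9 uM.

Compound 2 and compound 3 sit within the scatter of each other in this assay. Both steps from compound 1 go beyond the scatter: an at least 6.9-fold lower number from compound 1 to compound 2 (0.84 log units; beyond the scatter), the change being (methyl in place of hydrogen on a saturated chain carbon bound to an amine nitrogen and a saturated chain carbon), and an at least 7.5-fold lower number from compound 1 to compound 3 (0.87 log units; beyond the scatter), the change being (chloro in place of fluoro on an aromatic carbon). Both steps start from the limit of > 300 uM in this assay, at which 1 of the 3 values shown sits, and are therefore read as lower bounds.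

Compound 4 `CCCNC1=NS(=O)(=O)c2cc(Cl)ccc2N1` remains to be measured. The change from compound 3 is methyl in place of hydrogen on a saturated chain carbon, two bonds along the chain from an amine nitrogen. It is the same kind of change as that from compound 1 to compound 2, but not the same: there the methyl enters on a saturated chain carbon bound to an amine nitrogen and a saturated chain carbon, here on a saturated chain carbon two bonds along the chain from an amine nitrogen. The cores of compound 1 and compound 3 differ as given by chloro in place of fluoro on an aromatic carbon.

Among the measured compounds shown here, for compound 4 a step of a 1.6-fold lower number from compound 3 to compound 4 (0.20 log units; within the scatter) is expected, smaller than the one measured for compound 2 and uncertain in direction, resting on the value of compound 3 39.9 uM. The steps from compound 1 start at the limit of > 300 uM in this assay, at which 1 of the 3 values shown sits, and set only lower bounds for the size of such a change. Compound 4 is estimated at 25 uM, between 8 uM and 80 uM.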

Compound 4, concentration for half-maximal effect: 55.5 uM
The estimate for compound 4 lay 2.2-fold (0.35 log units) below the measured number; the measured number falls inside the stated range.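

In this assay, methyl in place of hydrogen on the chain of compound 3 gives a 1.4-fold higher number from compound 3 to compound 4 (0.14 log units; within the scatter), and this result does not match the step seen on the core of compound 1: the same change on two cores in this assay, an at least 6.9-fold lower number (0.84 log units; beyond the scatter) from compound 1 to compound 2 and a 1.4-fold higher number (0.14 log units; within the scatter) from compound 3 to compound 4, at least 9.6-fold (0.98 log units) apart, beyond the scatter of two such steps

The comparison shows that this kind of change cannot be carried from one core to the other in this series, but it does not show whether the core or the place of the methyl accounts for the gap, since the methyl enters on a saturated chain carbon bound to an amine nitrogen and a saturated chain carbon in compound 2 and on a saturated chain carbon two bonds along the chain from an amine nitrogen in compound 4. The step to compound 2 starts from the limit of compound 1, so its full size stays unknown: the limit of > 300 uM in this assay, at which 1 of the 4 values shown sits.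

The compounds shown leave open how the propylamino chain reads on the core of compound 1 and how the branched chain of compound 2 reads on the core of compound 3, the two pairs that would separate core from place. Also open, as far as these compounds go, is how a longer chain such as butylamino, or a bromo group in place of the chloro, would read.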